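Trifluoromethyl in place of ethyl: expected activity

A few compounds are considered here, and "the series" means these few. Any claim that something is new, unique, unknown or untested is made for them only; others in the source may bear on it.

Compound 2 `CCc1cccc(NC(=O)N[C@@H](C)c2ccccc2)c1` gives 100% in an ADME assay on the whole organism with Oryza sativa as the target, tested at 0.1 uM; on this read-out lower numbers stand for a stronger effect and higher numbers for a weaker effect at the one concentration tested. Compound 1 `CCc1cccc(NC(=O)N[C@H](C)c2ccccc2)c1` gives 97%, and compound 3 `CCc1ccc(NC(=O)N[C@H](C)c2ccccc2)cc1` gives 95%; compound 2 lies within the scatter of both. Going by the values given here, the only step between measured compounds, a number 3 percentage points higher from compound 1 to compound 2 (within the scatter), rests on the fact that compounds 1 and 2 differ only in the configuration as drawn and does not touch the group on the aromatic carbon. Compound 4 `C[C@H](NC(=O)Nc1cccc(C(F)(F)F)c1)c1ccccc1` differs from compound 2 by trifluoromethyl in place of ethyl on an aromatic carbon. Among the compounds with values here, no measured step covers this exchange, and the values of compound 1 and compound 3 lie within the scatter of each other. Hence no step beyond the scatter is expected, a number 3 percentage points lower from compound 2 to compound 4 (within the scatter). Compound 4 is estimated at 97%, between 85% and 100%.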

Compound 4, a percentage reported as activity, at one concentration (the size of the read-out at that concentration, not a potency): 94%
Compound 4: the middle estimate sits 3 percentage points above what was measured, within the range that was stated.
By their numbers in this assay, from the lowest: compounds 4, 3, 1 and 2 (each within the scatter of the next).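

In this assay the aromatic carbon meta to a large group now has a measured exchange, trifluoromethyl in place of ethyl, and the result is a number 6 percentage points lower from compound 2 to compound 4 (within the scatter). Ethyl is therefore not needed at this position to keep the read-out at this level, and trifluoromethyl, with its fluorine atoms, fits the same range of values. Nothing at hand gives a reason for this result.

On these data alone, whether an amine, a carboxylic acid or a longer chain at this carbon would move the read-out beyond the scatter stays open. Also open, as far as these compounds go, is how trifluoromethyl behaves with the opposite configuration as drawn.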